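The source may report more compounds than this note shows. Statements on the series, on what has been measured and on what is new or still open speak of the compounds shown alone.

Compound 1 `Cc1nc(C(NC(=O)C(=O)Nc2ccc(Cl)cc2)C2CCCCN2C)sc1CCO` — in an ADME assay on TZM-b1 cells (Homo sapiens) for cytotoxicity, read by XTT assay, with a stated time of 3 days (on this read-out higher numbers stand for lower toxicity in this test and lower numbers for higher toxicity in this test), compound 1 gives 36000 nM.
Compound 3 `Cc1nc(C(NC(=O)C(=O)Nc2ccc(Cl)c(F)c2)C2CCCCN2)sc1CO` — compound 3 gives 58400 nM.
Compound 2 `Cc1ccc(NC(=O)C(=O)NC(c2nc(C)c(CCO)s2)C2CCCCN2)c(F)c1` — for compound 2 the assay reports only a limit, > 78800 nM.

Among the two numbers shown, compound 1 stands lowest, and its nearest neighbour is compound 3, whose number lies within the usual scatter of compound 1. The third value is the limit of > 78800 nM in this assay, at which 1 of the 3 values shown sits, so it cannot be placed against the others as a number. The three measured compounds thus sit in a narrow band, and the change of ring on the amine side or of the aryl substituent does not separate them.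

Compound 4 `Cc1nc(C(NC(=O)C(=O)Nc2ccc(Cl)cc2)C2CCCN2)sc1CCO` has not been measured. It differs from compound 1 by pyrrolidin-2-yl in place of 1-methylpiperidin-2-yl on a saturated chain carbon bound to an amide-type nitrogen and an aromatic carbon.

Within the data shown here, no step between measured compounds is known. Because the values of compound 1 and compound 3 lie within the scatter and compound 2 sits at the limit of > 78800 nM in this assay, at which 1 of the 3 values shown sits, the expectation for compound 4 is a step from compound 1 of no more than the scatter, in no set direction, so that a 1.1-fold higher number from compound 1 to compound 4 (0.05 log units; within the scatter) is expected to be small. Compound 4 is therefore estimated at 40000 nM, with a range from 13000 nM to 100000 nM.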

Compound 4, half-maximal cytotoxic concentration: 4900 nM
Compound 4: middle estimate off by 8.2-fold (0.91 log units), on the high side, outside the stated range (below it).
By their numbers in this assay, from the lowest: compound 4; then compounds 1 and 3 (each within the scatter of the next). At a limit, above all of these: compound 2.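

At the position on a saturated chain carbon bound to an amide-type nitrogen and an aromatic carbon, pyrrolidin-2-yl in place of 1-methylpiperidin-2-yl gives a 7.3-fold lower number from compound 1 to compound 4 (0.87 log units; beyond the scatter) in this assay, and on this read-out the lower number stands for higher toxicity in this test. Among these compounds, the group at this position therefore matters for this read-out, which the earlier compounds could not show, as no step between them could be read. The change is a double one, since a five-membered ring replaces a six-membered ring and the entering group carries a hydrogen-bond donor that the leaving group lacks, and nothing measured here bears on the reason for the step.

The compounds shown leave open whether the ring size or the methyl group on the ring nitrogen carries the step, a question that 1-methylpyrrolidin-2-yl or piperidin-2-yl at this position on the core of compound 1 would address. They also leave open whether an open-chain amine such as dimethylaminomethyl at the same place would give a number nearer that of compound 1 or that of compound 4.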